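The compounds below may be only part of what the source reports. "The series", "measured", "known", "first", "only" and "open" are said of these compounds alone.

Values in a physicochemical assay for solubility, measured as kinetic solubility, at pH 7.4; on this read-out higher numbers stand for higher solubility and lower numbers for lower solubility:
- Compound 1 `COc1cc(N2CCN(C(=O)N3CCN(C)CC3)CC2)ccc1Nc1nc(NC2CCCCC2)c2nc[nH]c2n1`: 75000 nM
- Compound 2 `COc1cc(N2CCN(Cc3ccccn3)CC2)ccc1Nc1nc(NC2CCCCC2)c2nc[nH]c2n1`: 38000 nM
- Compound 3 `COc1cc(N2CCC(C(=O)N3CCC(N(C)C)C3)CC2)ccc1Nc1nc(NC2CCCCC2)c2nc[nH]c2n1`: 38000 nM

Compound 3 stands level with compound 2 at the digits shown, and its number and that of compound 1 lie within the usual scatter of each other. So these three compounds, despite their different side chains, cannot be told apart in this assay.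

The next molecule is compound 4 `COc1cc(N2CCC(CC(=O)N3CCOCC3)CC2)ccc1Nc1nc(NC2CCCCC2)c2nc[nH]c2n1`. It keeps the shared core, but ((morpholin-4-yl)carbonyl)methyl takes the place of (3-(dimethylamino)pyrrolidin-1-yl)carbonyl on a saturated ring carbon: ((morpholin-4-yl)carbonyl)methyl in place of (3-(dimethylamino)pyrrolidin-1-yl)carbonyl on a saturated ring carbon.

Going by the values given here, only one measured step connects compounds that differ in a single place: a 2.0-fold lower number from compound 1 to compound 2 (0.30 log units; within the scatter). It lies within the scatter, but it concerns a different ring and different groups, so it is only loose guidance. Among the compounds with values here, no measured step tests this exact exchange. The best anchor is therefore compound 3 at 38000 nM, with a slight lean towards a lower number as a matter of judgement and not of data. The expected change is small, a 1.9-fold lower number from compound 3 to compound 4 (0.28 log units; within the scatter), with no clear move beyond the scatter. For compound 4 the estimated value is 20000 nM, with an expected range from 6000 nM to 60000 nM.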

Compound 4, solubility: 19000 nM
Compound 4: middle estimate off by 1.1-fold (0.02 log units), on the high side; the range from low to high includes it.
By their numbers in this assay, from the lowest: compounds 4, 2, 3 and 1 (each within the scatter of the next, the first and the last beyond it).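

In this assay, the exchange on this saturated ring carbon gives a 2.0-fold lower number from compound 3 to compound 4 (0.30 log units; within the scatter), so this step cannot be told apart from repeat-measurement noise. Going by these compounds alone, it is the first comparison at this position, three ring bonds from the ring nitrogen, as the earlier step concerned an amine nitrogen in a ring, and here a five-membered ring with a dimethylamino group gives way to a six-membered morpholine ring, with no step beyond the scatter. The swap alters the ring, the hetero atoms and the link to the carbonyl all at once, and no measurement available here accounts for the size of the step or assigns it to any one of these features.

Still open, as far as these compounds go, is how the two parts of the change act separately, which (morpholin-4-yl)carbonyl placed directly on the ring carbon would help to separate from the extra methyl link. Also open, from the compounds shown here alone, is whether a carboxylic acid or a longer chain between the ring carbon and the carbonyl would give a step beyond the scatter at this position.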